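Isoquinolinyl in Place of Hydroxynaphthyl on the Urea

This account rests on a few compounds, and the source may have more. Where it says the series, first, only, none or still open, it means among the compounds named here.

In an assay on CHO cells for antagonist activity at transient receptor potential cation channel subfamily V member 1 (Homo sapiens), read by scintillation counting, with a stated time of 5 min, in the presence of a further agent that is not named here (on this read-out higher numbers stand for an effect only at larger amounts of compound and lower numbers for an effect already at smaller amounts), three compounds were measured:
compound 1 `CN(C)C1(Cc2ccccc2)CCN(c2cc(C(F)(F)F)ccc2CNC(=O)Nc2cccc3ccc(O)cc23)CC1`: 8.9 nM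
compound 2 `CN(C)C1(Cc2ccccc2)CCN(c2cc(C(F)(F)F)ccc2CNC(=O)Nc2ccc3c(c2)OCC3)CC1`: 31.3 nM
compound 3 `CN(C)C1(Cc2ccccc2)CCN(c2cc(C(F)(F)F)ccc2CNC(=O)Nc2ccc3cccnc3c2)CC1`: 42 nM

Compound 1 has the lowest of the three numbers. Its nearest neighbour is compound 2, reached by a 3.5-fold higher number from compound 1 to compound 2 (0.55 log units; beyond the scatter); the furthest is compound 3, reached by a 4.7-fold higher number from compound 1 to compound 3 (0.67 log units; beyond the scatter). Between compounds 2 and 3 the step is a 1.3-fold higher number from compound 2 to compound 3 (0.13 log units; within the scatter).

Compound 4 `CN(C)C1(Cc2ccccc2)CCN(c2cc(C(F)(F)F)ccc2CNC(=O)Nc2cccc3cnccc23)CC1` is not yet measured in this assay. It differs from compound 1 in one place: isoquinolin-5-yl in place of 7-hydroxynaphthalen-1-yl on an amide-type nitrogen. Within the data shown here, the step that bears most on this change is the one from compound 1 to compound 3, where a bicyclic aromatic group holding one nitrogen and no hydroxyl replaced the same 7-hydroxynaphthalen-1-yl and gave a 4.7-fold higher number from compound 1 to compound 3 (0.67 log units; beyond the scatter); the step to compound 2, which also removed the hydroxyl, gave a 3.5-fold higher number from compound 1 to compound 2 (0.55 log units; beyond the scatter). A step of similar size and direction is therefore expected for compound 4, namely a 4.5-fold higher number from compound 1 to compound 4 (0.65 log units; beyond the scatter). Compound 4 is estimated at 40 nM, with a range of 12 nM to 130 nM.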

Compound 4, half-maximal effective concentration: 8.8 nM
For compound 4 the middle estimate is 4.5-fold (0.66 log units) above the measured one, outside the stated range (below it).
By their numbers in this assay, from the lowest: compounds 4 and 1 (each within the scatter of the next); then compounds 2 and 3 (each within the scatter of the next).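

In this assay, among these compounds, the earlier steps had left the hydroxyl of 7-hydroxynaphthalen-1-yl looking like a requirement at this amide-type nitrogen, but isoquinolin-5-yl, with 0 hydrogen-bond donors, shows otherwise, with a 1.0-fold lower number from compound 1 to compound 4 (0.00 log units; within the scatter). The identity of the nitrogen-containing bicyclic group clearly matters, since a 4.8-fold lower number from compound 3 to compound 4 (0.68 log units; beyond the scatter) when isoquinolin-5-yl replaces quinolin-7-yl, and there is a 3.6-fold lower number from compound 2 to compound 4 (0.55 log units; beyond the scatter) on the change from the oxygen-containing group of compound 2, so losing the hydroxyl does not by itself decide the outcome. Nothing available accounts for these differences.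

On these data alone, whether an unsubstituted naphthalen-1-yl, quinolin-5-yl or a methoxy group in place of the hydroxyl would fit with compounds 1 and 4 or with compounds 2 and 3 remains open. As far as these compounds go, it is also open whether a hydroxyl or an amine added to isoquinolin-5-yl would change the number in this assay.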